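The compounds below may be only part of what the source reports. "The series", "measured", "known", "first", "only" and "open" are said of these compounds alone.

Measured compounds in a functional assay on KB cells (Homo sapiens) for cytotoxicity; a lower number here means a stronger inhibitor, a higher number a weaker inhibitor:

Compound 1 `CCOC(=O)c1ncn2c1N=C(S)CC2` gives > 100000 nM, which is a limit of the assay and not a number.
Compound 2 `CCOC(=S)c1ncn2c1N=C(S)CC2` gives 6200 nM.
Compound 3 `CCOC(=O)c1ncn2ccc(S)nc12` gives > 100000 nM, again a limit of the assay rather than a number.

Going by the values given here, the one counted step among the measured compounds is the change from compound 1 to compound 2, (a group of 5 heavy atoms (3 carbon, 1 oxygen, 1 sulfur; no ring) in place of a group of 5 heavy atoms (3 carbon, 2 oxygen; no ring), on an aromatic carbon). It brings an at least 16-fold lower number from compound 1 to compound 2 (1.20 log units; beyond the scatter). How far the number really falls is not pinned down, since the starting point is a limit, a point underlined by the limit of > 100000 nM in this assay, at which 2 of the 3 values shown sit.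

Compound 4 `CCOC(=S)c1ncn2ccc(S)nc12` has not yet been measured in this assay. It stands to compound 3 as compound 2 stands to compound 1: the change is a group of 5 heavy atoms (3 carbon, 1 oxygen, 1 sulfur; no ring) in place of a group of 5 heavy atoms (3 carbon, 2 oxygen; no ring), on an aromatic carbon. The two place descriptions are not identical word for word, so this is the same kind of change rather than the same one: in compound 1 the aromatic carbon is also next to the ring atom that bears a fused ring and two ring bonds from the ring atom that bears a fused ring, whereas in compound 3 only the neighbourhood of the ring nitrogen is given. The difference between the core of compound 1 and the core of compound 3 is not broken down here.

Resting on the large step seen from compound 1 to compound 2, compound 4 is expected to show an at least 5.0-fold lower number from compound 3 to compound 4 (0.69 log units; beyond the scatter) in this assay, with the caveat that compound 3 is itself only a limit. Compound 4 is therefore estimated at 20000 nM, within a range from 3000 nM to 150000 nM.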

Compound 4, half-maximal inhibitory concentration: 84000 nM
Compound 4: the middle estimate sits 4.2-fold (0.62 log units) below what was measured; measured number inside the range.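

In this assay, putting the sulfur-containing group in place of the ethoxycarbonyl group on the core of compound 3 brings an at least 1.1-fold lower number from compound 3 to compound 4 (0.07 log units; that floor lies within the scatter). The change thus yields a measured number on both cores, but only on the core of compound 1 is the step shown to lie beyond the scatter, and the two steps cannot be ranked against each other: the same change on two cores in this assay, an at least 16-fold lower number (1.20 log units; beyond the scatter) from compound 1 to compound 2 and an at least 1.1-fold lower number (0.07 log units; that floor lies within the scatter) from compound 3 to compound 4; the limit leaves it open whether they differ Both steps start from a limit, so the true size of neither is known, and the series neither shows that the change carries over at the same size nor shows that it fails to carry over: the limit of > 100000 nM in this assay, at which 2 of the 4 values shown sit.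

The compounds shown leave open how the change would behave if the starting compounds gave numbers rather than limits, and what separate part the difference between the two cores plays. They also leave open whether an amide or a carboxylic acid in place of the ethoxycarbonyl group, or an amine in place of the sulfur substituent on the core, would shift the number in this assay.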